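From phenyl to ethynyl on the shared core

The compounds below may be only part of what the source reports. "The series", "measured", "known", "first", "only" and "open" are said of these compounds alone.

In a functional assay on K562 cells (Homo sapiens), read by MTT assay, with a stated time of 72 h (a higher number here means a weaker inhibitor, a lower number a stronger inhibitor), compound 1 (`C#Cc1cn([C@@H]2O[C@H](CO)[C@@H](O)[C@H]2O)c2ncnc(OC)c12`) gives 300 nM as its measured value. Compound 2 (`CNc1ncnc2c1c(-c1ccccc1)cn2[C@@H]1O[C@H](CO)[C@@H](O)[C@H]1O`) gives > 20000 nM as a limit of the assay and not a number. Compound 3 (`C#Cc1cn([C@@H]2O[C@H](CO)[C@@H](O)[C@H]2O)c2ncnc(NC)c12`) has ethynyl in place of phenyl on an aromatic carbon. Compound 1 also bears ethynyl and stands at 300 nM in this assay so a shift toward stronger inhibition, beyond the scatter, is expected. The estimated step is an at least 20-fold lower number from compound 2 to compound 3 (1.30 log units; beyond the scatter) in this assay and it remains uncertain since compound 2 has only a limit. Compound 3 is expected at 1000 nM (estimated range 150 nM to 8000 nM).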

Compound 3, half-maximal inhibitory concentration: > 20000 nM
Compound 3: a limit, no number; the forecaster's own chance of this, stated with the estimate: 15%; middle value at least 20-fold (1.30 log units) from the limit.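

With ethynyl kept on this aromatic carbon, that group alone does not carry the activity of compound 1: methylamino in place of methoxy on an aromatic carbon gives an at least 66-fold higher number from compound 1 to compound 3 (1.82 log units; beyond the scatter) in this assay. The effect of changing phenyl to ethynyl cannot be read because compound 2 and compound 3 both stand as limits of the assay, not numbers: the limit of > 20000 nM in this assay, at which 2 of the 3 values shown sit.

As far as these compounds go, it remains open how phenyl or a longer chain such as propynyl would read on this carbon with methoxy kept. From the compounds shown here alone, it is also open whether an unsubstituted amine in place of methylamino would read nearer compound 1 or compound 3.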